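The compounds below may be only part of what the source reports. "The series", "measured", "known", "first", "only" and "open" are said of these compounds alone.

For the measured compounds named here, compound 2 `O=C1C(=O)N(Cc2ccc(-c3ccccc3)cc2)c2ccc(OC(F)(F)F)cc21` is one of two compounds measured so far in a functional assay on CHO cells for positive allosteric modulation of muscarinic acetylcholine receptor M5 (Homo sapiens), read by FLIPR and calcium flux, with a stated time of 1 h; on this read-out lower numbers stand for an effect already at smaller amounts and higher numbers for an effect only at larger amounts of compound; here compound 2 gives 1600 nM. Its companion, compound 1 `O=C1C(=O)N(Cc2ccc(-c3cccnc3)cc2)c2ccc(OC(F)(F)F)cc21`, gives 1600 nM in this assay, so the two stand level at the digits shown. Going by the values given here, the single step known between them, no change at the digits printed from compound 1 to compound 2 (within the scatter), shows that swapping one of these two rings for the other left the read-out unchanged within the usual scatter.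

Compound 3 `O=C1C(=O)N(Cc2ccc(-c3ccncc3)cc2)c2ccc(OC(F)(F)F)cc21` has not yet been measured. It differs from compound 2 in one place: pyridin-4-yl in place of phenyl on an aromatic carbon. Among the compounds with values here, the only step that bears on this change is the one from compound 1 to compound 2, where exchanging a pyridine ring for a phenyl ring made no difference. Exchanging the phenyl for a pyridine ring of another kind is therefore expected to give no change at the digits printed from compound 2 to compound 3 (within the scatter), no step beyond the scatter. For compound 3 the expected value is 1600 nM, within a range from 700 nM to 3600 nM.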

Compound 3, half-maximal effective concentration: 2800 nM
For compound 3 the middle estimate is 1.8-fold (0.24 log units) below the measured one, and the stated range covers the measured number.
By their numbers in this assay, from the lowest: compounds 1, 2 and 3 (each within the scatter of the next).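

In this assay, putting pyridin-4-yl on this aromatic carbon gives a 1.8-fold higher number from compound 2 to compound 3 (0.24 log units; within the scatter) and a 1.8-fold higher number from compound 1 to compound 3 (0.24 log units; within the scatter). The earlier pair covered only phenyl and pyridin-3-yl, whereas this result adds a third six-membered aromatic ring, and the three cannot be told apart at this position, even though pyridin-4-yl counts one hydrogen-bond acceptor and phenyl none. No separate measurement bears on why these rings read alike. The compounds shown leave open how this position responds to a group of a different kind, such as an amine, a carboxylic acid or a longer chain in place of the ring. They also leave open whether a substituent on the ring itself, such as a methoxy group or a fluorine atom, would move the read-out beyond the scatter.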